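This account rests on a few compounds, and the source may have more. Where it says the series, first, only, none or still open, it means among the compounds named here.

Measured so far:

Compound 1, `CCCCn1cnc2c(Nc3ccccc3)nc(NCOCc3ccc(/C=C/C(=O)Nc4ccccc4N)cc3)nc21`: 59.3%
Compound 2, `Nc1ccccc1NC(=O)c1ccc(Cn2cnc3c(Nc4ccc(-c5ccccn5)cc4)nc(Cl)nc32)cc1`: 41.2%

Of the compounds shown here, two have been measured in a functional assay on HepG2 cells (Homo sapiens) for antiproliferative activity, read by CCK-8 assay, with a stated time of 72 h, tested at 8 uM; on this read-out lower numbers stand for a weaker effect and higher numbers for a stronger effect at the one concentration tested. Compound 1 gives 59.3%, and compound 2 gives 41.2%. Compound 2 therefore stands at the lower of the two numbers, with compound 1 higher by a margin beyond the scatter; as the two structures differ in several places at once, no single step can be read from them.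

The next compound, compound 3, `Cc1ccc(Nc2nc(Cl)nc3c2ncn3Cc2ccc(C(=O)Nc3ccccc3N)cc2)cc1`, is to be measured in this assay. It differs from compound 2 in one place: methyl in place of pyridin-2-yl on an aromatic carbon. The change sits on a six-membered aromatic ring of carbon only, para to a large group.

Within the data shown here, with no measured step of this kind to lean on, compound 3 is expected to move downward by a small amount, a number 6.2 percentage points lower from compound 2 to compound 3 (within the scatter), roughly within the scatter. Compound 3 is thus estimated at 35%, between 20% and 50%.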

Compound 3, a percentage reported as inhibition, at one concentration (the size of the read-out at that concentration, not a potency): 82%
Beside the measured number, compound 3's estimate is 47 percentage points below it; measured number above the stated range.
By their numbers in this assay, from the lowest: compound 2; then compound 1; then compound 3.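

In this assay, putting methyl in place of pyridin-2-yl on an aromatic carbon, para to a large group, gives a number 40.8 percentage points higher from compound 2 to compound 3 (beyond the scatter) and so provides the only single-place comparison among the compounds shown. At this position, the pyridin-2-yl ring is therefore not required for a strong effect at the one concentration tested, and the change from 4-(pyridin-2-yl)phenyl to 4-methylphenyl raises the read-out well beyond what was seen before. No measured evidence bears on what lies behind a step of this size.

Whether the rise comes from losing the pyridine ring or from gaining the methyl group stays open, since no compound with hydrogen, methoxy or an unsubstituted phenyl ring on this carbon is among those shown. Going by these compounds, it is also open whether the step would hold if the chlorine on the shared core gave way to an amine.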